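The source may hold more compounds than are shown below. What is called first, only, known or untested is meant among the compounds shown, and "the series" means these compounds.

Of the compounds shown here, two of the shared core have been measured in a functional assay on SW707 cells (Homo sapiens) for antiproliferative activity, with a stated time of 72 h; a lower number here means a stronger inhibitor, a higher number a weaker inhibitor. Compound 1 `OCC#CCSc1cnc2ccccc2c1SCC#CCCl` gives 19.8 ug/mL there, and compound 2 `CCOC(=O)OCC#CCSc1c(SC)cnc2ccccc12` gives 33.1 ug/mL in this assay; the two values lie within the usual scatter of each other, so compound 2 is not separated from compound 1 on the numbers shown. Compound 3 `CSc1cnc2ccccc2c1SCC#CCCl` follows from compound 2 by chloro in place of (ethoxycarbonyl)oxy on a saturated chain carbon bound to a triple-bonded carbon. Within the data shown here, no measured pair shows this change, so its size is unknown from the data. Compound 3 carries the chloro end of compound 1, whose 19.8 ug/mL lies close to compound 2. The step of a 1.5-fold lower number from compound 2 to compound 3 (0.18 log units; within the scatter) is expected to stay within the scatter. Compound 3 is estimated at 22 ug/mL in this assay, range 10 ug/mL to 45 ug/mL.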

Compound 3, concentration for 50% inhibition: 3.7 ug/mL
Estimate against measurement, compound 3: 5.9-fold (0.77 log units) above; the whole stated range lies above it.
By their numbers in this assay, from the lowest: compound 3; then compounds 1 and 2 (each within the scatter of the next).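

In this assay, the step of an 8.9-fold lower number from compound 2 to compound 3 (0.95 log units; beyond the scatter) shows that the group on a saturated chain carbon bound to a triple-bonded carbon can move the number beyond the scatter when chloro replaces (ethoxycarbonyl)oxy. With the chloro end kept, hydrogen in place of 3-hydroxyprop-1-yn-1-yl on a saturated chain carbon bound to a sulfur gives a 5.4-fold lower number from compound 1 to compound 3 (0.73 log units; beyond the scatter), so this second place also matters. Nothing available explains either step.

As far as these compounds go, whether bromo, fluoro or an amine in place of chloro would keep the lower number remains open. So does the effect of a longer chain in place of hydrogen on the saturated chain carbon bound to a sulfur.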